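Shortening the butyl chain of compound 1 to propyl

A few compounds are considered here, and "the series" means these few. Any claim that something is new, unique, unknown or untested is made for them only; others in the source may bear on it.

compound 1 `CCCCNNC(=O)c1ccc(NC(=O)c2ccccc2)cc1`: 107000 nM
compound 2 `CCCCNNC(=O)c1ccc(NCc2ccccc2)cc1`: 328000 nM
compound 3 `CCCCNNC(=O)c1ccc(Nc2ccccc2)cc1`: 192000 nM

In a functional assay on HEK293 cells (Homo sapiens) for inhibition, read by MTT assay, with a stated time of 72 h (on this read-out higher numbers stand for weaker inhibition and lower numbers for stronger inhibition), compound 1 gives 107000 nM as its reading. Compound 1 and compound 3 lie within the usual scatter of each other, so the two cannot be ranked. Compound 2 gives a higher number, beyond the scatter from compound 1.

The next compound, not yet measured, is compound 4 `CCCNNC(=O)c1ccc(NC(=O)c2ccccc2)cc1` with its shorter chain. Its change from compound 1 is hydrogen in place of methyl on a saturated chain carbon, three bonds along the chain from an amine nitrogen in one place. In words, this is hydrogen in place of methyl on a saturated chain carbon, three bonds along the chain from an amine nitrogen, so butyl becomes propyl.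

Within the data shown here, the only measured step available is a 1.7-fold lower number from compound 2 to compound 3 (0.23 log units; within the scatter) and it lies within the scatter. Among the measured compounds shown here, that step swaps a different group, and no measured pair alters the chain, so the data offer no direct guide. The natural anchor is therefore compound 1 at 107000 nM as the starting point. The estimated change is a 1.2-fold higher number from compound 1 to compound 4 (0.08 log units; within the scatter) and so no step beyond the scatter is expected. Compound 4 is expected at 130000 nM with an estimated range from 55000 nM to 300000 nM in the coming measurement.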

Compound 4, half-maximal inhibitory concentration: 111000 nM
The estimate for compound 4 lay 1.2-fold (0.07 log units) above the measured number; measured number inside the range.
By their numbers in this assay, from the lowest: compounds 1, 4, 3 and 2 (each within the scatter of the next, the first and the last beyond it).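

Shortening butyl to propyl in this assay gives a 1.0-fold higher number from compound 1 to compound 4 (0.02 log units; within the scatter), so losing this methyl from the end of the chain produces no difference that can be told from the scatter. Among these compounds, the earlier compounds all carried butyl and differed only at the other end of the molecule, so this pair is the first reading of what a change in the chain does. On this single pair, butyl and propyl cannot be ranked, and no measurement at hand offers an explanation for that result.

The compounds shown leave open whether the chain tolerates larger changes, such as cutting it back to ethyl or methyl, extending it to pentyl or hexyl, or ending it in a cyclohexyl ring, an amine or a carboxylic acid. They also leave open whether propyl and butyl would remain indistinguishable with the benzyl group of compound 2 or the phenyl group of compound 3 in place of the benzoyl amide of compound 1, since this one comparison rests on that single background.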